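This account rests on a few compounds, and the source may have more. Where it says the series, first, only, none or still open, it means among the compounds named here.

Compound 2 `CCCCCCCn1nc(-c2ccccc2)c(-c2ccccc2)cc1=O` gives 86000 nM in an assay on microsomes from liver for inhibition of sterol O-acyltransferase 1 (Rattus norvegicus) (on this read-out higher numbers stand for weaker inhibition and lower numbers for stronger inhibition), the lowest of the two numbers shown. Compound 1 `CC(C)n1nc(-c2ccccc2)c(-c2ccccc2)cc1=O` gives 152000 nM in this assay, and the step of a 1.8-fold lower number from compound 1 to compound 2 (0.25 log units; within the scatter) lies within the scatter. Compound 3 `O=c1cc(-c2ccccc2)c(-c2ccccc2)nn1C1CCCCC1` reaches only a limit of this assay, > 300000 nM, which is the limit of > 300000 nM in this assay, at which 1 of the 3 values shown sits. Measured from compound 2 the step is an at least 3.4-fold higher number from compound 2 to compound 3 (0.54 log units; beyond the scatter), and measured from compound 1 it is an at least 1.9-fold higher number from compound 1 to compound 3 (0.29 log units; that floor lies within the scatter).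

Compound 4 `O=C(O)CCCCCCCn1nc(-c2ccccc2)c(-c2ccccc2)cc1=O` differs from compound 2 by carboxy in place of hydrogen on a saturated chain carbon, seven bonds along the chain from an aromatic nitrogen. Among the compounds with values here, no measured step adds a group to the chain; each of the three replaces the whole group on the aromatic nitrogen. Within the data shown here, the only steps that bear on the heptyl chain are the exchange of isopropyl for heptyl, within the scatter, and the exchange of heptyl for cyclohexyl, at least modest. Among the measured compounds shown here, the carboxy has no counterpart in the measured compounds, so the expectation is a step of no more than modest size, and the expected change is a 1.2-fold higher number from compound 2 to compound 4 (0.07 log units; within the scatter). Compound 4 is therefore estimated at 100000 nM, between 30000 nM and 300000 nM.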

Compound 4, half-maximal inhibitory concentration: > 300000 nM
Compound 4 was reported as a limit (the forecaster's own chance of this, stated with the estimate: 25%); at least 3.0-fold (0.47 log units) between middle value and limit.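

Carboxy in place of hydrogen on a saturated chain carbon, seven bonds along the chain from an aromatic nitrogen, is the first change shown that keeps the heptyl chain and alters only its far end, and in this assay it gives an at least 3.4-fold higher number from compound 2 to compound 4 (0.54 log units; beyond the scatter). This position is therefore not indifferent to the change, and the weakening it brings lies beyond the scatter, whereas the exchange of the whole group in a 1.8-fold lower number from compound 1 to compound 2 (0.25 log units; within the scatter) does not. The step is only a floor, and compound 4, like compound 3, is reported as a limit of the assay: the limit of > 300000 nM in this assay, at which 2 of the 4 values shown sit.

The compounds shown leave open whether a hydroxy group, an amine or a methyl ester at the same chain end would weaken inhibition as well, and whether a shorter chain such as 3-carboxypropyl would. Going by these compounds, how compound 4 ranks against compound 3 also stays open.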